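Swapping dichlorophenyl for bromophenyl on the shared core

The source may report more compounds than this note shows. Statements on the series, on what has been measured and on what is new or still open speak of the compounds shown alone.

Compound 3, `C=CCn1c(=O)/c(=C\c2cccc(Cl)c2Cl)[nH]c(=O)/c1=C\c1ccccc1OC`, is the reference point here. In a functional assay on NCI-H1975 cells (Homo sapiens) for cytotoxicity, read by CCK-8 assay, with a stated time of 72 h (on this read-out lower numbers stand for stronger inhibition and higher numbers for weaker inhibition), compound 3 gives 4500 nM. Among the compounds with a number it has the lowest, but compound 1, `C=CCn1c(=O)/c(=C\c2cccc(Cl)c2)[nH]c(=O)/c1=C\c1ccccc1OC`, sits close: in this assay compound 1 gives 5100 nM, and the step of a 1.1-fold lower number from compound 1 to compound 3 (0.05 log units; within the scatter) is within the scatter, so the two cannot be ranked. Compound 2, `COc1ccccc1/C=c1/[nH]c(=O)/c(=C\c2cccc(Cl)c2Cl)[nH]c1=O`, is reported in this assay as "not active" (no number reported), with no number attached.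

Compound 4, `C=CCn1c(=O)/c(=C\c2cccc(Br)c2)[nH]c(=O)/c1=C\c1ccccc1OC`, differs from compound 3 by 3-bromophenyl in place of 2,3-dichlorophenyl on a double-bonded chain carbon bound to an aromatic carbon. Among the compounds with values here, the one measured step that bears on this is a 1.1-fold lower number from compound 1 to compound 3 (0.05 log units; within the scatter), where adding a chloro to the aromatic ring changed nothing beyond the scatter. Compound 4 undoes that added chloro and exchanges the remaining chlorine for bromine at the same place. Within the data shown here, with the only relevant step flat, no change beyond the scatter is expected in this assay, and the step from compound 3 to compound 4 is estimated as a 1.1-fold higher number from compound 3 to compound 4 (0.03 log units; within the scatter). For compound 4 the expected value in this assay is 4800 nM, with a range from 2200 nM to 11000 nM.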

Compound 4, half-maximal inhibitory concentration: "not active" (no number reported)
The entry for compound 4 holds no number, and the estimate cannot be compared.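

Within the data shown here, compound 4 carries no number in this assay, so no step from compound 3 to compound 4 can be read. Nothing shown here offers an explanation for this result. The compounds shown leave open how large the effect of 3-bromophenyl in place of 2,3-dichlorophenyl on the shared core is in this assay.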